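This account rests on a few compounds, and the source may have more. Where it says the series, first, only, none or still open, it means among the compounds named here.

Compound 1 `CCCCCCn1cnc2c(Nc3cccc(Cl)c3)nc(N[C@H]3CC[C@H](N)CC3)nc21` gives 2700 nM
Compound 2 `CCCCn1cnc2c(Nc3cc(OC)cc(OC)c3)nc(N[C@H]3CC[C@H](N)CC3)nc21` gives 4500 nM
Compound 3 `CCCCn1cnc2c(Nc3ccc(Cl)cc3)nc(N[C@H]3CC[C@H](N)CC3)nc21` gives 2100 nM

These values come from a functional assay on MCF7 cells (Homo sapiens) for inhibition, read by fluorescence, with a stated time of 72 h (on this read-out higher numbers stand for weaker inhibition of growth and lower numbers for stronger inhibition of growth), and compound 3 lies within the usual scatter of compound 1. Compound 4 `CCCCn1cnc2c(Nc3cccc(Cl)c3)nc(N[C@H]3CC[C@H](N)CC3)nc21` has 3-chlorophenyl in place of 4-chlorophenyl on a nitrogen on an aromatic ring. For the measured compounds named here, the only measured step at this place is modest: a 2.1-fold lower number from compound 2 to compound 3 (0.33 log units; beyond the scatter) and it involved a different pair of groups. Compound 1 also carries 3-chlorophenyl, though with a hexyl chain instead of butyl, and gives 2700 nM so it offers only loose support. No step beyond the scatter is therefore expected in this assay and the expected change is a 1.1-fold higher number from compound 3 to compound 4 (0.06 log units; within the scatter) as the estimate stands. Compound 4 is estimated at 2400 nM with a range from 1200 nM to 4800 nM expected.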

Compound 4, concentration for 50% growth inhibition: 2000 nM
Estimate against measurement, compound 4: 1.2-fold (0.08 log units) above, and the stated range covers the measured number.
By their numbers in this assay, from the lowest: compounds 4, 3, 1 and 2 (each within the scatter of the next, the first and the last beyond it).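

In this assay, 3-chlorophenyl in place of 4-chlorophenyl gives a 1.1-fold lower number from compound 3 to compound 4 (0.02 log units; within the scatter), so these two chlorophenyl groups cannot be told apart here. Replacing 3,5-dimethoxyphenyl with 3-chlorophenyl gives a 2.3-fold lower number from compound 2 to compound 4 (0.35 log units; beyond the scatter), a modest step like the one to 4-chlorophenyl. Shortening hexyl to butyl while 3-chlorophenyl stays in place gives a 1.4-fold lower number from compound 1 to compound 4 (0.13 log units; within the scatter), so this chain change also cannot be read as a real difference. From the compounds shown here alone, whether plain phenyl or a ring carrying an amine or a carboxylic acid would move the number stays open. No measurement shown explains these results.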